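This account rests on a few compounds, and the source may have more. Where it says the series, first, only, none or still open, it means among the compounds named here.

Three compounds sharing one core have been examined in a functional assay on cells (Homo sapiens) for inhibition, read by MTT assay, with a stated time of 48 h; a higher number here means a weaker inhibitor, a lower number a stronger inhibitor. Compound 1 (`O=S(=O)(c1ccccc1)c1c(OCCCCCCO)no[n+]1[O-]`), which ends in a plain alcohol chain, has no usable result and stands as "not determined" (no result reported). Compound 2 (`O=C(CCCCOc1no[n+]([O-])c1S(=O)(=O)c1ccccc1)NO`) gives 4300 nM. Compound 3 (`O=C(COCCOc1no[n+]([O-])c1S(=O)(=O)c1ccccc1)NO`) gives 19800 nM, the higher of the two numbers available. Compound 4 (`CC(C)(COc1no[n+]([O-])c1S(=O)(=O)c1ccccc1)C(=O)NO`) has not yet been measured. It differs from compound 3 as follows: 1-(hydroxycarbamoyl)-1-methylethyl in place of ((hydroxycarbamoyl)methoxy)methyl on a saturated chain carbon bound to an oxygen on an aromatic ring. The chain thus loses its (hydroxycarbamoyl)methoxy part and carries a 1-(hydroxycarbamoyl)-1-methylethyl group instead. For the measured compounds named here, only one measured step bears on this change: a 4.6-fold higher number from compound 2 to compound 3 (0.66 log units; beyond the scatter). Going by the values given here, that step introduced the (hydroxycarbamoyl)methoxy group, which compound 4 no longer has, but no measured compound carries the 1-(hydroxycarbamoyl)-1-methylethyl group. A partial return of modest size towards the number of compound 2 is therefore expected, with considerable uncertainty. The expected change is a 2.2-fold lower number from compound 3 to compound 4 (0.34 log units; beyond the scatter). Compound 4 is estimated at 9000 nM, with an expected range of 3000 nM to 25000 nM.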

Compound 4, half-maximal inhibitory concentration: 18300 nM
Estimate against measurement, compound 4: 2.0-fold (0.31 log units) below, and the stated range covers the measured number.
By their numbers in this assay, from the lowest: compound 2; then compounds 4 and 3 (each within the scatter of the next).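

In this assay, the step to the 1-(hydroxycarbamoyl)-1-methylethyl group is a 1.1-fold lower number from compound 3 to compound 4 (0.03 log units; within the scatter), so this place on the chain does not separate that group from ((hydroxycarbamoyl)methoxy)methyl. The step from 3-(hydroxycarbamoyl)propyl to the same group is a 4.3-fold higher number from compound 2 to compound 4 (0.63 log units; beyond the scatter), which shows that losing the (hydroxycarbamoyl)methoxy part does not by itself bring the number back to that of compound 2, and compound 2 keeps the lowest number of the three. Nothing available gives a reason for this result.

As far as these compounds go, it remains open whether the number of compound 2 depends on its unbranched chain, as a longer chain carrying the same hydroxycarbamoyl end would test. From the compounds shown here alone, it also remains open how a carboxylic acid in place of the hydroxycarbamoyl end would compare.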